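Ester to dimethylamide: notes on compound 3

This account rests on a few compounds, and the source may have more. Where it says the series, first, only, none or still open, it means among the compounds named here.

In an ADME assay on HeLa cells (Homo sapiens) for cytotoxicity, read by crystal violet staining, with a stated time of 72 h (on this read-out higher numbers stand for lower toxicity in this test and lower numbers for higher toxicity in this test), compound 1 `CCOC(=O)c1cc(CCCOc2ccc(-c3noc(C(F)(F)F)n3)cc2)on1` gives > 100000 nM, which is a limit of the assay and not a number. Compound 2 `CCOC(=O)c1cc(CCCOc2ccc(-c3noc(C(F)(F)F)n3)cc2[N+](=O)[O-])on1` gives > 100000 nM, likewise a limit. Within the data shown here, the one measured step is a step that the two limits leave unreadable from compound 1 to compound 2, with nitro in place of hydrogen on an aromatic carbon. Among the measured compounds shown here, the series so far amounts to the limit of > 100000 nM in this assay, at which 2 of the 2 values shown sit.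

Compound 3 `CN(C)C(=O)c1cc(CCCOc2ccc(-c3noc(C(F)(F)F)n3)cc2)on1` departs from compound 1 in one place: dimethylamino in place of ethoxy on a carbonyl carbon. Cut one bond further out, this reads ethoxycarbonyl to dimethylcarbamoyl. The nitro step gives no size to carry over. Resting on a step that the two limits leave unreadable from compound 1 to compound 2 and on (the limit of > 100000 nM in this assay, at which 2 of the 2 values shown sit), no step beyond the scatter is expected in this assay, and no direction can be set. The expected step is a number no higher from compound 1 to compound 3 (the limit leaves the size open). For compound 3 the estimated value is 100000 nM, with an expected range of 40000 nM to 200000 nM.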

Compound 3, half-maximal cytotoxic concentration: 28000 nM
Compound 3: middle estimate off by 3.6-fold (0.55 log units), on the high side; the measured number lies below the stated range.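

In this assay, the substituent on the carbonyl carbon proves able to move the read-out: dimethylamino in place of ethoxy gives an at least 3.5-fold lower number from compound 1 to compound 3 (0.55 log units; beyond the scatter), so toxicity in this test is higher for the amide. Among these compounds, compound 3 gives 28000 nM, the only value shown that is a number and not a limit of the assay. This sets the amide apart from the two ethyl esters, which give no readable step between them and no size for the nitro change: the limit of > 100000 nM in this assay, at which 2 of the 3 values shown sit.

The compounds shown do not tell whether this step belongs to dimethylamino itself or would appear with any replacement of ethoxy, such as a primary amide or a carboxylic acid on the same carbonyl carbon. On these data alone, whether nitro on the aromatic carbon would shift the amide's number also stays open.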